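A few compounds are considered here, and "the series" means these few. Any claim that something is new, unique, unknown or untested is made for them only; others in the source may bear on it.

Compound 1 `CCOC(=O)c1sc2ccc(NCc3c[nH]cn3)cc2c1NC(=O)c1ccc(C(F)(F)F)cc1` carries a 4-(trifluoromethyl)phenyl on the amide carbonyl, and in a functional assay on HeLa cells (Homo sapiens) for antiproliferative activity, read by MTT assay, with a stated time of 48 h (on this read-out lower numbers stand for stronger inhibition of growth and higher numbers for weaker inhibition of growth), compound 1 gives 16800 nM. Compound 2 `CCOC(=O)c1sc2ccc(NCc3c[nH]cn3)cc2c1NC(=O)c1ccc(F)c(Cl)c1` differs by 3-chloro-4-fluorophenyl in place of 4-(trifluoromethyl)phenyl on a carbonyl carbon; in this assay compound 2 gives 10700 nM, a step of a 1.6-fold lower number from compound 1 to compound 2 (0.20 log units; within the scatter). Compound 3 `CCOC(=O)c1sc2ccc(NCc3nc[nH]c3C)cc2c1NC(=O)c1ccc(C(F)(F)F)cc1` keeps the 4-(trifluoromethyl)phenyl but differs from compound 1 by methyl in place of hydrogen on an aromatic carbon; in this assay compound 3 gives 12800 nM, a step of a 1.3-fold lower number from compound 1 to compound 3 (0.12 log units; within the scatter). Compound 4 `CCOC(=O)c1sc2ccc(NCc3nc[nH]c3C)cc2c1NC(=O)c1ccc(F)c(Cl)c1` has not been measured. It differs from compound 3 by 3-chloro-4-fluorophenyl in place of 4-(trifluoromethyl)phenyl on a carbonyl carbon, the same change that leads from compound 1 to compound 2, at the same place. The step from compound 3 to compound 4 is therefore expected to be a 1.5-fold lower number from compound 3 to compound 4 (0.18 log units; within the scatter), resting on the earlier step of a 1.6-fold lower number from compound 1 to compound 2 (0.20 log units; within the scatter). On this basis compound 4 is estimated at 8500 nM, with a likely range from 4000 nM to 18000 nM.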

Compound 4, concentration for 50% growth inhibition: 2910 nM
For compound 4 the middle estimate is 2.9-fold (0.47 log units) above the measured one; the whole stated range lies above it.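

In this assay the exchange of 4-(trifluoromethyl)phenyl for 3-chloro-4-fluorophenyl did not carry over unchanged from one core to the other, giving a 4.4-fold lower number from compound 3 to compound 4 (0.64 log units; beyond the scatter): the same change on two cores in this assay, a 1.6-fold lower number (0.20 log units; within the scatter) from compound 1 to compound 2 and a 4.4-fold lower number (0.64 log units; beyond the scatter) from compound 3 to compound 4, 2.8-fold (0.45 log units) apart, beyond the scatter of two such steps. The methyl in place of hydrogen on an aromatic carbon likewise did not carry over unchanged, giving a 3.7-fold lower number from compound 2 to compound 4 (0.57 log units; beyond the scatter): the same change on two cores in this assay, a 1.3-fold lower number (0.12 log units; within the scatter) from compound 1 to compound 3 and a 3.7-fold lower number (0.57 log units; beyond the scatter) from compound 2 to compound 4, 2.8-fold (0.45 log units) apart, beyond the scatter of two such steps. Within the data shown here, the two changes together therefore gave more than their single steps would suggest, but these four compounds form a single case and show neither why this happens nor whether it extends to other groups.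

The compounds shown leave open whether the same holds with an unsubstituted phenyl or a cyclohexyl on the carbonyl carbon. They also leave open the outcome with an ethyl group in place of the methyl, or with a carboxylic acid in place of the ethyl ester.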